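Swapping one aryl group for another on a ring nitrogen

The source may report more compounds than this note shows. Statements on the series, on what has been measured and on what is new or still open speak of the compounds shown alone.

The compounds here share one fused core, shown in compound 1 `CC(C)[C@@H]1CC[C@@H](C)C[C@@]12N(C)C(=O)[C@@H]1[C@H]3C(=O)NC(=O)[C@H]3ON12`, for which compound 1 has "not determined" (no result reported) in a functional assay, read by spectrophotometry, with a stated time of 2 h; on this read-out higher numbers stand for weaker inhibition and lower numbers for stronger inhibition. Compound 2 `CC(C)[C@@H]1CC[C@@H](C)C[C@@]12N(C)C(=O)[C@@H]1[C@H]3C(=O)N(C)C(=O)[C@H]3ON12` gives 2160 ug/mL in this assay. Compound 3 `COc1ccc(N2C(=O)[C@H]3[C@H](ON4[C@@H]3C(=O)N(C)[C@@]43C[C@H](C)CC[C@H]3C(C)C)C2=O)cc1` gives 990 ug/mL in this assay, the lowest of the two numbers reported, and the step of a 2.2-fold lower number from compound 2 to compound 3 (0.34 log units; beyond the scatter) is modest but beyond the scatter. The new compound 4 `Cc1ccc(N2C(=O)[C@H]3[C@H](ON4[C@@H]3C(=O)N(C)[C@@]43C[C@H](C)CC[C@H]3C(C)C)C2=O)c(C)c1` differs from compound 3 in one place: 2,4-dimethylphenyl in place of 4-methoxyphenyl on an amide-type nitrogen in a ring. Within the data shown here, no measured step exchanges one aryl group for another at this position; the only measured step puts an aryl group in place of a methyl, and it was modest. A change from one aryl group to another is therefore expected to move this assay less, if at all, so compound 4 is expected to land within the scatter of compound 3, with the step of a 1.1-fold lower number from compound 3 to compound 4 (0.04 log units; within the scatter) expected to be small. The estimate for compound 4 in this assay is 900 ug/mL, with a range from 400 ug/mL to 2000 ug/mL.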

Compound 4, half-maximal inhibitory concentration: 430 ug/mL
Estimate against measurement, compound 4: 2.1-fold (0.32 log units) above; the measured number falls inside the stated range.
By their numbers in this assay, from the lowest: compound 4; then compound 3; then compound 2.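

At this ring nitrogen, the choice of aryl group matters and not only its presence: 2,4-dimethylphenyl in place of 4-methoxyphenyl gives a 2.3-fold lower number from compound 3 to compound 4 (0.36 log units; beyond the scatter) in this assay and so moves the number beyond the scatter, even though the two groups have the same count of heavy atoms. Set against the methyl group of compound 2, the same aryl group gives a 5.0-fold lower number from compound 2 to compound 4 (0.70 log units; beyond the scatter) and leaves compound 4 with the lowest number of the three, with its steps to both others beyond the scatter, although each step is still modest. Nothing available explains why the number falls with this exchange.

On these data alone, it remains open whether both methyl groups of 2,4-dimethylphenyl are needed, a question that 4-methylphenyl at this nitrogen could help settle. As far as these compounds go, how an unsubstituted phenyl or a benzyl group would read here is also open.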